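A Methyl Added to the Phenyl of Compound 3

This account rests on a few compounds, and the source may have more. Where it says the series, first, only, none or still open, it means among the compounds named here.

Compound 1 `Nc1cccc(-c2cn3nc(-c4cccs4)sc3n2)c1`: in a functional assay on FM3A cells (Mus musculus) for inhibition, read by cell counting, with a stated time of 2 days (on this read-out higher numbers stand for weaker inhibition and lower numbers for stronger inhibition), compound 1 gives > 250000 nM, which is a limit of the assay rather than a number.
Compound 2 `C=C(Br)C(=O)Nc1cccc(-c2cn3nc(Cc4cccc(OC)c4)sc3n2)c1`: in this assay compound 2 gives 1100 nM.
Compound 3 `C=C(Br)C(=O)Nc1cccc(-c2cn3nc(-c4ccccc4)sc3n2)c1`: in this assay compound 3 gives 900 nM.

Compound 3 and compound 2 give numbers that lie within the usual scatter of each other, so neither can be called the stronger; compound 1 sits at a limit and gives no number to compare. Within the data shown here, the one measured step, a 1.2-fold lower number from compound 2 to compound 3 (0.09 log units; within the scatter), shows that swapping the whole group on that aromatic carbon left the number essentially where it was.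

Compound 4 `C=C(Br)C(=O)Nc1cccc(-c2cn3nc(-c4ccc(C)cc4)sc3n2)c1` differs from compound 3 by methyl in place of hydrogen on an aromatic carbon. Among the measured compounds shown here, no measured step here adds or removes a methyl, so the only guide is the step from compound 2 to compound 3, which was within the scatter even for a far larger exchange at the same position. A small addition is therefore expected to produce no step beyond the scatter in this assay. This amounts to an expected 1.1-fold lower number from compound 3 to compound 4 (0.05 log units; within the scatter). Compound 4 is estimated at 800 nM, with a likely range from 300 nM to 2500 nM.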

Compound 4, half-maximal inhibitory concentration: 1200 nM
The estimate for compound 4 lay 1.5-fold (0.18 log units) below the measured number; low and high end bracket the measured number.
By their numbers in this assay, from the lowest: compounds 3, 2 and 4 (each within the scatter of the next). At a limit, above all of these: compound 1.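

Methyl in place of hydrogen, on the aromatic carbon para to a large group, is the first small change shown on this phenyl ring, and in this assay it gives a 1.3-fold higher number from compound 3 to compound 4 (0.12 log units; within the scatter). The larger exchange gives a 1.1-fold higher number from compound 2 to compound 4 (0.04 log units; within the scatter), so 3-methoxybenzyl, phenyl and 4-methylphenyl at this aromatic carbon now all lie within the scatter of one another. Nothing measured here explains why these three numbers stay so close.

From the compounds shown here alone, whether an amine, a carboxylic acid or a longer chain on this phenyl ring would leave the number within the scatter remains open. Compound 1 gives > 250000 nM, which is a limit of the assay, and it differs from the other compounds in more than one place, so it cannot show which difference matters.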